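Trimethoxyphenyl amide on the chlorobenzyl-indole thiazole

A few compounds are considered here, and "the series" means these few. Any claim that something is new, unique, unknown or untested is made for them only; others in the source may bear on it.

Measured so far:
compound 1 `COc1cc(NC(=O)c2csc(-c3c[nH]c4ccc(Br)cc34)n2)cc(OC)c1OC` — > 100000 nM in a functional assay on PC-3 cells (Homo sapiens) for cytotoxicity, read by MTT assay, with a stated time of 48 h, in the presence of a further agent that is not named here; on this read-out lower numbers stand for stronger inhibition and higher numbers for weaker inhibition
compound 2 `O=C(Nc1ccccc1)c1csc(-c2cn(Cc3ccc(Cl)cc3)c3ccccc23)n1` — > 100000 nM in this assay

Both recorded values are limits of this assay rather than numbers. Compound 1 sits at the limit of > 100000 nM. Compound 2 likewise gives only the limit of > 100000 nM, so it stands among the two compounds for which the limit of > 100000 nM in this assay, at which 2 of the 2 values shown sit, applies. Compound 3 `COc1cc(NC(=O)c2csc(-c3cn(Cc4ccc(Cl)cc4)c4ccccc34)n2)cc(OC)c1OC` is not yet measured; it differs from compound 2 by 3,4,5-trimethoxyphenyl in place of phenyl on an amide-type nitrogen. The same amide group is carried by compound 1 without any measurable effect. Going by the values given here, no measured step exists here, so the expectation for compound 3 rests on two limits. It is expected that a number no higher from compound 2 to compound 3 (the limit leaves the size open) stays within the scatter. Compound 3 is estimated at 100000 nM, from 20000 nM to 300000 nM, most likely again as a limit.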

Compound 3, half-maximal inhibitory concentration: > 100000 nM
Compound 3: no number, only a limit; the forecaster's own chance of this, stated with the estimate: 70%; the middle value sits exactly at the limit.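

Compound 2 and compound 3 give no readable step, as each value is a limit and not a number: the limit of > 100000 nM in this assay, at which 3 of the 3 values shown sit.

The compounds shown leave open whether 3,4,5-trimethoxyphenyl in place of phenyl changes potency, and whether any compound here reaches a measurable value.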